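Furan isomer swap on a ribosyl pyrrolopyrimidinone core

The compounds below may be only part of what the source reports. "The series", "measured", "known", "first", "only" and "open" are said of these compounds alone.

Measured so far:
compound 1 `Nc1nc(N)c2c(-c3ccsc3)cn([C@@H]3O[C@H](CO)[C@@H](O)[C@H]3O)c2n1` — > 20000 nM
compound 2 `O=c1[nH]cnc2c1c(-c1ccoc1)cn2[C@@H]1O[C@H](CO)[C@@H](O)[C@H]1O` — 12100 nM
compound 3 `COc1ncnc2c1c(-c1cccs1)cn2[C@@H]1O[C@H](CO)[C@@H](O)[C@H]1O` — 13900 nM

In a functional assay on HepG2 cells (Homo sapiens) for antiproliferative activity, read by XTT assay, with a stated time of 72 h (a higher number here means a weaker inhibitor, a lower number a stronger inhibitor), compound 1 reports only a limit, > 20000 nM, and not a number. In this assay compound 2 gives 12100 nM. In this assay compound 3 gives 13900 nM. Compound 2 thus carries the lower of the two numbers shown, yet the gap to compound 3 lies within the scatter, so no order between the two can be stated. The one other point is the limit of > 20000 nM in this assay, at which 1 of the 3 values shown sits, which belongs to compound 1 alone.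

Compound 4 `O=c1[nH]cnc2c1c(-c1ccco1)cn2[C@@H]1O[C@H](CO)[C@@H](O)[C@H]1O` is the next member to be measured. It differs from compound 2 in one place: furan-2-yl in place of furan-3-yl on an aromatic carbon. Going by the values given here, no pair of measured compounds differing only in such a place exists in this set, so no measured step can be pointed to; both compounds keep the same core and the same sugar.

The expectation is therefore anchored on compound 2. Given that the change moves a furan-2-yl in for a furan-3-yl at the same aromatic carbon, the expected step of a 1.0-fold lower number from compound 2 to compound 4 (0.00 log units; within the scatter) is none beyond the scatter. Compound 4 is accordingly estimated at 12000 nM, within a range from 5000 nM to 30000 nM, with a real chance that only a limit is returned.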

Compound 4, half-maximal inhibitory concentration: > 15000 nM
Compound 4 ended at the assay's limit (the forecaster's own chance of this, stated with the estimate: 25%); middle value at least 1.2-fold (0.09 log units) away from the limit.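

In this assay compound 4 returns only a limit, > 15000 nM, and not a number. Going by these compounds alone, the change of furan-3-yl to furan-2-yl, on an aromatic carbon two ring bonds from the ring nitrogen, gives the first single-place step, read as an at least 1.2-fold higher number from compound 2 to compound 4 (0.09 log units; that floor lies within the scatter). Both groups hold the same atoms, so only the furan's point of attachment differs, and this first reading at the position is bounded on one side only, with a floor that does not separate the two isomers: the limit of > 15000 nM in this assay, at which 1 of the 4 values shown sits.

Within the data shown here, whether compound 4 truly lies apart from compound 2 stays open, as does whether any group on this aromatic carbon can move the number beyond the scatter, given that the furan swap is the only single-place step available. A plain phenyl at the same carbon, or an amine or a carboxylic acid carried on the furan-3-yl ring of compound 2, would show how far this position tolerates change with the shared core and sugar kept.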